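A few compounds are considered here, and "the series" means these few. Any claim that something is new, unique, unknown or untested is made for them only; others in the source may bear on it.

Measured so far in a functional assay on HepG2 cells (Homo sapiens) for antiproliferative activity, read by CCK-8 assay, with a stated time of 72 h; on this read-out higher numbers stand for weaker inhibition and lower numbers for stronger inhibition:
compound 1 `Cc1ccccc1C(=O)Nc1cccc(-c2oc3cc(-c4ccc(F)cc4)ccc3c(=O)c2O)c1` gives 19400 nM
compound 2 `O=C(Nc1cccc(-c2oc3cc(-c4ccc(F)cc4)ccc3c(=O)c2O)c1)c1cccc(F)c1` gives 15500 nM

For the measured compounds named here, compound 2 holds the lowest of the two numbers in this assay, though the only measured step, a 1.3-fold lower number from compound 1 to compound 2 (0.10 log units; within the scatter), lies within the scatter. Compound 3 `CCCc1ccc(C(=O)Nc2cccc(-c3oc4cc(-c5ccc(F)cc5)ccc4c(=O)c3O)c2)cc1` differs from compound 2 by 4-propylphenyl in place of 3-fluorophenyl on a carbonyl carbon. Going by the values given here, the one step that bears on this, the exchange of one aryl group for another on the same carbonyl carbon, left the number essentially unchanged, so no step beyond the scatter is expected in this assay. Compound 3 is therefore expected to give 14000 nM, between 6000 nM and 35000 nM, a step of a 1.1-fold lower number from compound 2 to compound 3 (0.04 log units; within the scatter).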

Compound 3, half-maximal inhibitory concentration: 51500 nM
For compound 3 the middle estimate is 3.7-fold (0.57 log units) below the measured one, and the stated range ends below it.
By their numbers in this assay, from the lowest: compounds 2 and 1 (each within the scatter of the next); then compound 3.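

Exchanging the aryl group on the carbonyl carbon is not always silent in this assay: 4-propylphenyl in place of 3-fluorophenyl gives a 3.3-fold higher number from compound 2 to compound 3 (0.52 log units; beyond the scatter) and in place of 2-methylphenyl gives a 2.7-fold higher number from compound 1 to compound 3 (0.42 log units; beyond the scatter) in this series. For the compounds shown here, the earlier exchange had stayed within the scatter, so this is the first sign that inhibition here responds to the group, and the response is a weakening. Nothing measured here accounts for the loss.

On these data alone, it remains open whether the propyl chain itself matters or only the way it is attached to the phenyl ring. Also open, as far as these compounds go, is how a shorter chain such as ethyl, or an amine or a carboxylic acid on that ring, would read.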